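A few compounds are considered here, and "the series" means these few. Any claim that something is new, unique, unknown or untested is made for them only; others in the source may bear on it.

Measured so far in a functional assay on BV-2 cells (Mus musculus) for inhibition, read by Griess assay, with stated times of 3 h and 24 h; on this read-out higher numbers stand for weaker inhibition and lower numbers for stronger inhibition:
compound 1, `O=S(=O)(/C=C/c1ccc(O)c(O)c1)Cc1ccccc1`, gives 11600 nM;
compound 2, `O=S(=O)(/C=C/c1ccc(O)c(O)c1)CCc1ccccc1`, gives 30600 nM;
compound 3, `[O-][S+](/C=C/c1ccc(O)c(O)c1)CCc1ccccc1`, gives 42600 nM.

Compound 2 differs from compound 1 by benzyl in place of phenyl on a saturated chain carbon bound to a sulfonyl sulfur. This change made a 2.6-fold higher number from compound 1 to compound 2 (0.42 log units; beyond the scatter). Compound 3 and compound 1 differ in their cores; that difference is not broken down here. Compound 3 and compound 2 sit within the scatter of each other.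

Compound 4, `[O-][S+](/C=C/c1ccc(O)c(O)c1)CCCc1ccccc1`, is not yet measured. It differs from compound 3 by benzyl in place of phenyl on a saturated chain carbon, two bonds along the chain from a sulfur. This is the same kind of change as from compound 1 to compound 2, but not the same: there the carbon is bound to a sulfonyl sulfur, here it is two bonds along the chain from a sulfur. One prior instance on a different core is a thin basis. Compound 4 is expected to show a 2.1-fold higher number from compound 3 to compound 4 (0.32 log units; beyond the scatter) in this assay, resting on a 2.6-fold higher number from compound 1 to compound 2 (0.42 log units; beyond the scatter). Compound 4 is therefore estimated at 90000 nM, between 35000 nM and 220000 nM.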

Compound 4, half-maximal inhibitory concentration: 28600 nM
The estimate for compound 4 lay 3.1-fold (0.50 log units) above the measured number; measured number outside the range, below it.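

Benzyl in place of phenyl, on a saturated chain carbon two bonds along the chain from a sulfur, gives a 1.5-fold lower number from compound 3 to compound 4 (0.17 log units; within the scatter) in this assay. The change therefore does not carry over as a fixed step between these two cores: the same change on two cores in this assay, a 2.6-fold higher number (0.42 log units; beyond the scatter) from compound 1 to compound 2 and a 1.5-fold lower number (0.17 log units; within the scatter) from compound 3 to compound 4, 3.9-fold (0.59 log units) apart, beyond the scatter of two such steps. The earlier rise cannot be applied to this core, but with one pair on each core, the data do not show which difference between the cores matters or how the change behaves on any other core.

Still open, on these data alone, is whether a longer chain would continue the flat picture on the core of compound 3. Also open, as far as these compounds go, is how an amine or a carboxylic acid in place of the terminal phenyl would read out.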